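The compounds below may be only part of what the source reports. "The series", "measured", "known", "first", "only" and "open" are said of these compounds alone.

Of the compounds shown here, three have been measured in an assay on HEK293 cells for positive allosteric modulation of metabotropic glutamate receptor 5 (Homo sapiens), read by FLIPR, with a stated time of 1 h; on this read-out lower numbers stand for an effect already at smaller amounts and higher numbers for an effect only at larger amounts of compound. Compound 1 `COc1ccccc1C#Cc1nc2c(s1)C(=O)NCC2` gives only a limit, > 10000 nM. Compound 2 `O=C1c2sc(C#Cc3ccccc3)nc2CN1C1CC1` likewise gives only a limit, > 10000 nM. Going by the values given here, compound 3 `CCCCN1CCc2nc(C#Cc3ccccc3)sc2C1` gives 110 nM, the only actual number among the three, since the other two sit at the limit of > 10000 nM in this assay, at which 2 of the 3 values shown sit. Compound 4 `O=C(C1CCCO1)N1CCc2nc(C#Cc3ccccc3)sc2C1` has not yet been measured. It differs from compound 3 in one place: (oxolan-2-yl)carbonyl in place of butyl on an amine nitrogen in a ring. Among the compounds with values here, no measured pair differs in a single place, so no step for this change can be read from the data. The expectation for compound 4 is nonetheless a weakening in this assay, a step of a 14-fold higher number from compound 3 to compound 4 (1.13 log units; beyond the scatter) beyond the usual scatter, with a real chance that only a limit is reported. The estimate for compound 4 is 1500 nM, within 300 nM to 10000 nM.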

Compound 4, half-maximal effective concentration: 790 nM
Estimate against measurement, compound 4: 1.9-fold (0.28 log units) above, within the range that was stated.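

Going by these compounds alone, on the amine nitrogen in the ring, (oxolan-2-yl)carbonyl in place of butyl gives in this assay a 7.2-fold higher number from compound 3 to compound 4 (0.86 log units; beyond the scatter), the first step that can be read at this position. This nitrogen can therefore carry a carbonyl-linked ring at a moderate cost, without activity being lost. Compound 4 still gives an actual number, unlike the compounds that stand at a limit: the limit of > 10000 nM in this assay, at which 2 of the 4 values shown sit.

The compounds shown leave open whether the carbonyl or the oxolane ring accounts for the weakening. They also leave open how a plain acetyl group or a benzyl group would behave on this nitrogen.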